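A few compounds are considered here, and "the series" means these few. Any claim that something is new, unique, unknown or untested is made for them only; others in the source may bear on it.

Compound 1 `O=S(=O)(c1ccc(F)cc1)c1cccc2oc(N3CCNCC3)nc12`: 64 nM
Compound 2 `O=S(=O)(c1ccc(C(F)(F)F)cc1)c1cccc2oc(N3CCNCC3)nc12`: 33 nM
Compound 3 `O=S(=O)(c1cccc2ccccc12)c1cccc2oc(N3CCNCC3)nc12`: 3.1 nM

In an assay on HeLa cells for displacement of a labelled ligand from 5-hydroxytryptamine receptor 6 (Homo sapiens) (on this read-out lower numbers stand for stronger inhibition and higher numbers for weaker inhibition), compound 3 stands lowest of the three numbers; its gaps to compound 2 and to compound 1 both lie beyond the scatter. Compound 4 `O=S(=O)(c1cccc2ccccc12)c1cccc2oc(N3CCN(C4CCC4)CC3)nc12` differs from compound 3 by cyclobutyl in place of hydrogen on an amine nitrogen in a ring. Among the measured compounds shown here, the only measured step, a 1.9-fold lower number from compound 1 to compound 2 (0.29 log units; within the scatter), concerns the aromatic ring of the sulfonyl group and does not touch the amine nitrogen in the ring, so no measured step bears on this change. With nothing to indicate a direction, compound 4 is expected to remain close to compound 3, at an estimated 5 nM with a range of 1.5 nM to 20 nM. The expected step, a 1.6-fold higher number from compound 3 to compound 4 (0.21 log units; within the scatter), is estimated to fall within the scatter.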

Compound 4, inhibition constant: 72 nM
For compound 4 the middle estimate is 14-fold (1.16 log units) below the measured one; measured number above the stated range.
By their numbers in this assay, from the lowest: compound 3; then compounds 2, 1 and 4 (each within the scatter of the next, the first and the last beyond it).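

In this assay, among the compounds shown here, the amine nitrogen in the ring proves sensitive to substitution, which the earlier compounds could not show, as they differ only on the aromatic ring of the sulfonyl group. Cyclobutyl in place of hydrogen there gives a 23-fold higher number from compound 3 to compound 4 (1.37 log units; beyond the scatter) and so weakens inhibition well beyond the scatter. Nothing available explains this step.

The compounds shown leave open whether a methyl group, a longer chain or an open-chain amine on that nitrogen would cost as much. They also leave open whether cyclobutyl has the same effect alongside the fluoro or trifluoromethyl aryl sulfonyl groups.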